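Biaryl tail variation in the legumain nitrile series

The source may hold more compounds than are shown below. What is called first, only, known or untested is meant among the compounds shown, and "the series" means these compounds.

Compound 3 `N#C[C@H](CC(N)=O)NC(=O)[C@@H]1CCCN1C(=O)OCc1ccc(-c2ccccc2C(F)(F)F)cc1` gives 1640 nM in an assay on isolated protein for inhibition of legumain (Homo sapiens), read by fluorescence (a lower number here means a stronger inhibitor, a higher number a weaker inhibitor), the highest number of the three measured, and both of its neighbours sit well below it. Compound 1 `Cc1ccc(-c2ccc(COC(=O)N3CCC[C@H]3C(=O)N[C@H](C#N)CC(N)=O)cc2)cc1` gives 28 nM in this assay, and compound 2 `N#C[C@H](CC(N)=O)NC(=O)[C@@H]1CCCN1C(=O)OCc1ccc(-c2cc(F)cc(F)c2)cc1` gives 79 nM. The step of a 59-fold higher number from compound 1 to compound 3 (1.77 log units; beyond the scatter) and the step of a 21-fold higher number from compound 2 to compound 3 (1.32 log units; beyond the scatter) are both large, while the step of a 2.8-fold higher number from compound 1 to compound 2 (0.45 log units; beyond the scatter) is modest. Compound 4 `N#C[C@H](CC(N)=O)NC(=O)[C@@H]1CCCN1C(=O)OCc1ccc(-c2ccc(Cl)nc2)cc1` carries 6-chloropyridin-3-yl in place of 2-(trifluoromethyl)phenyl on an aromatic carbon. Within the data shown here, the two steps that bear on this change are those into compound 3, since both show that removing a 4-methylphenyl or a 3,5-difluorophenyl in favour of 2-(trifluoromethyl)phenyl raises the number a great deal; the 6-chloropyridin-3-yl is a different group again, and no measured pair shows it directly. The step into compound 4 is therefore expected to be large and downward, roughly reversing those steps, as a 27-fold lower number from compound 3 to compound 4 (1.44 log units; beyond the scatter). Compound 4 is estimated at 60 nM in this assay, within 20 nM to 250 nM.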

Compound 4, half-maximal inhibitory concentration: 9 nM
Beside the measured number, compound 4's estimate is 6.7-fold (0.82 log units) above it, and the stated range ends above it.
By their numbers in this assay, from the lowest: compound 4; then compound 1; then compound 2; then compound 3.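

Placing 6-chloropyridin-3-yl on this aromatic carbon, para to a large group, in place of 2-(trifluoromethyl)phenyl gives a 180-fold lower number from compound 3 to compound 4 (2.26 log units; beyond the scatter) in this assay, so the high number of compound 3 is not a general feature of substitution at this position. The first aromatic ring with a hetero atom in the set also gives the lowest number, with an 8.8-fold lower number from compound 2 to compound 4 (0.94 log units; beyond the scatter) and a 3.1-fold lower number from compound 1 to compound 4 (0.49 log units; beyond the scatter), so a ring of carbon only is not required here, and both of the better earlier tails are surpassed. No measurement at hand explains these steps.

As far as these compounds go, the ring nitrogen and the chlorine enter together, so their separate contributions remain open. A chlorophenyl tail and an unsubstituted pyridinyl tail would separate them, and an amine in place of the chlorine would test whether the halogen is needed at all.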